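The compounds below may be only part of what the source reports. "The series", "measured", "known", "first", "only" and "open" are said of these compounds alone.

Measured compounds:
Compound 1, `CC(c1ccc(Cl)c(Cl)c1)c1ccccc1CN(C)C`: "not determined" (no result reported) in an assay on HEK293 cells for inhibition of sodium-dependent dopamine transporter (Homo sapiens); a higher number here means a weaker inhibitor, a lower number a stronger inhibitor.
Compound 2, `CNCc1ccccc1Cc1ccc(SC)cc1`: 5900 nM in this assay.
Compound 3, `CN(C)Cc1ccccc1Oc1ccc(C#N)cc1`: "not determined" (no result reported) in this assay.

Only compound 2 carries a number. Compound 3 stands without one: two of the three measured compounds, compound 1 and compound 3, ended without a reported result, so nothing fixes where compound 3 sits. The shared core of compound 3, a dimethylaminomethyl-bearing ring linked by an oxygen to a second aromatic ring, is kept in compound 4, `CN(C)Cc1ccccc1Oc1ccc(CC2CC2)cc1`, and the change is cyclopropylmethyl in place of cyano on an aromatic carbon.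

Going by the values given here, no pair of measured compounds differs in one place, so no step of the kind needed to read this change has been seen, and the size and direction of the step from compound 3 to compound 4 cannot be drawn from the data. With compound 2 as the only anchor, compound 4 is expected to land in the same broad region, near the weak end of measurable inhibition. The value of compound 4 is estimated at 2500 nM, within a range from 400 nM to 15000 nM.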

Compound 4, half-maximal inhibitory concentration: 16000 nM
Estimate against measurement, compound 4: 6.4-fold (0.81 log units) below; the measured number lies above the stated range.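

Going by these compounds alone, compound 3 has no single number, so no step to compound 4 can be read. No supporting evidence bears on this result. What the compounds shown leave open is whether cyclopropylmethyl in place of cyano strengthens or weakens inhibition in this assay.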